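Swapping the indole substituent on a shared triaryl methane core

The compounds below may be only part of what the source reports. "The series", "measured", "known", "first", "only" and "open" are said of these compounds alone.

Measured so far in a functional assay on C-33-A cells (Homo sapiens) for cytotoxicity; a lower number here means a stronger inhibitor, a higher number a weaker inhibitor:
- compound 1 `O=[N+]([O-])c1ccc2[nH]cc(C(c3ccccc3)c3cc4ccccc4o3)c2c1` gives 35200 nM
- compound 2 `CC(C)(C)c1cc(C(C)(C)C)c2oc(C(c3ccc(Cl)cc3)c3c[nH]c4ccccc34)cc2c1` gives 34200 nM
- compound 3 `Cc1[nH]c2ccccc2c1C(c1ccc(Cl)cc1)c1cc2cc(C(C)(C)C)cc(C(C)(C)C)c2o1` gives 31200 nM

All three compounds share a central saturated carbon carrying three aromatic groups. Compound 3 has the lowest of the three numbers, but its gap to compound 2 and to compound 1 is within the scatter, so none of the three can be called stronger or weaker than another. Within the data shown here, the only single-point step measured, a 1.1-fold lower number from compound 2 to compound 3 (0.04 log units; within the scatter), moved nothing beyond the scatter.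

Compound 4 `CC(C)(C)c1cc(C(C)(C)C)c2oc(C(c3ccc(Cl)cc3)c3c[nH]c4ccc([N+](=O)[O-])cc34)cc2c1` is the next compound, differing from compound 3 in one place: 5-nitro-1H-indol-3-yl in place of 2-methyl-1H-indol-3-yl on a saturated chain carbon bound to two aromatic carbons. Among the measured compounds shown here, no measured step covers this exact exchange. Compound 1 also carries the 5-nitro-1H-indol-3-yl group, though on a different core, and its number sits in the same range as the others. For the measured compounds named here, with three near-identical values and no step that has moved the number, no change beyond the scatter is expected for compound 4, so a 1.1-fold higher number from compound 3 to compound 4 (0.02 log units; within the scatter) is the estimate. Compound 4 is therefore expected to give about 33000 nM in this assay, in the range 15000 nM to 75000 nM.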

Compound 4, half-maximal inhibitory concentration: 29400 nM
The estimate for compound 4 lay 1.1-fold (0.05 log units) above the measured number; the range from low to high includes it.
By their numbers in this assay, from the lowest: compounds 4, 3, 2 and 1 (each within the scatter of the next).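

In this assay, among these compounds, adding a nitro group to the indole gives a 1.2-fold lower number from compound 2 to compound 4 (0.07 log units; within the scatter), the first measured look at this group on this core, and the number does not move beyond the scatter. The exchange of 5-nitro-1H-indol-3-yl for 2-methyl-1H-indol-3-yl on a saturated chain carbon bound to two aromatic carbons gives a 1.1-fold lower number from compound 3 to compound 4 (0.03 log units; within the scatter), so this change also leaves the number within the scatter. Nothing available explains why these changes leave the number in place.

On these data alone, it remains open whether any other group on the indole, such as an amine or a carboxylic acid in place of the nitro group, would shift the number beyond the scatter. As far as these compounds go, what the two tert-butyl groups on the shared core contribute also stays open.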